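Biaryl ester series: piperidinylmethyl replacing methoxy

The compounds below may be only part of what the source reports. "The series", "measured", "known", "first", "only" and "open" are said of these compounds alone.

Compound 2 `CCOC(=O)c1cccc(-c2ccc(OC)cc2)c1` gives 77% in an assay on COS-7 cells for inhibition of patatin-like phospholipase domain-containing protein 2 (Mus musculus), tested at 200 uM (a higher number here means more inhibition at the concentration tested (going by the name of the read-out), a lower number less inhibition), the higher of the two numbers recorded so far. Compound 1 `CCOC(=O)C1CCCC(c2ccc(OCC)cc2)N1` gives 48% in this assay, a reading that falls beyond the scatter below compound 2. Compound 3 `CCOC(=O)c1cccc(-c2ccc(CN3CCCCC3)cc2)c1` is unmeasured and differs from compound 2 by one change: (piperidin-1-yl)methyl in place of methoxy on an aromatic carbon. Within the data shown here, no measured pair spans this change, so its effect is unknown. With compound 2 at 77%, a step from compound 2 to compound 3 of a number 7 percentage points lower from compound 2 to compound 3 (within the scatter) is expected, a small drop within the scatter. Compound 3 is estimated at 70%, with a range from 45% to 90%.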

Compound 3, a percentage reported as inhibition, at one concentration (the size of the read-out at that concentration, not a potency): 68%
Beside the measured number, compound 3's estimate is 2 percentage points above it; the range from low to high includes it.
By their numbers in this assay, from the lowest: compound 1; then compounds 3 and 2 (each within the scatter of the next).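

On an aromatic carbon para to a large group, (piperidin-1-yl)methyl can stand in place of methoxy: in this assay the change gives a number 9 percentage points lower from compound 2 to compound 3 (within the scatter). This position therefore holds a group with a six-membered non-aromatic ring as well as the smaller methoxy, with no step beyond the scatter. No available evidence bears on this result.

Still open, from the compounds shown here alone, is whether the ring matters, which a dimethylamino group at this position would test. Going by these compounds, a carboxylic acid or a longer chain there also remains unexplored.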